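The compounds below may be only part of what the source reports. "The series", "measured", "known", "first", "only" and "open" are said of these compounds alone.

Working notes on the series. The shared core is seen in compound 2 `CCc1nnsc1CO/N=C/c1c(C)nn(C)c1Oc1ccccc1Cl`. In a functional assay on PANC-1 cells (Homo sapiens) for inhibition, read by MTT assay, with a stated time of 48 h (on this read-out higher numbers stand for weaker inhibition and lower numbers for stronger inhibition), compound 2 gives > 50000 nM, which is a limit of the assay and not a number. Compound 1 `Cc1ccc(Oc2c(/C=N/OCc3snnc3C)c(C)nn2C)cc1` sits at the same point: in this assay compound 1 gives > 50000 nM, again a limit rather than a number. Compound 2 therefore stands nowhere distinct on the numbers shown; both values sit at the limit, as summarised by the limit of > 50000 nM in this assay, at which 2 of the 2 values shown sit. Going by the values given here, no step between measured compounds is available.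

Compound 3 `CCc1nnsc1CO/N=C/c1c(C)nn(C)c1Oc1ccc(C)cc1` has not been measured in this assay. It differs from compound 2 in one place: 4-methylphenyl in place of 2-chlorophenyl on an oxygen on an aromatic ring. Compound 2 shows only a limit in this assay, and compound 1, which also carries 4-methylphenyl on that oxygen, shows only a limit, so no step beyond the scatter is expected in either direction. The estimated step from compound 2 to compound 3 is a step that the limit leaves unreadable from compound 2 to compound 3. Compound 3 is expected at 80000 nM, within 30000 nM to 300000 nM, and most likely reported once more only as a limit.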

Compound 3, half-maximal inhibitory concentration: > 50000 nM
Compound 3: only a limit was reported (the forecaster's own chance of this, stated with the estimate: 85%); the middle value does not contradict the limit.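

Compound 3 joins compound 1 and compound 2 at a limit rather than a number, so no step can be read among these compounds: the limit of > 50000 nM in this assay, at which 3 of the 3 values shown sit. The compounds shown leave open which change to the shared core, if any, would give a measurable value in this assay.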